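From methyl to cyclohexyl, and then to pentyl

The source may report more compounds than this note shows. Statements on the series, on what has been measured and on what is new or still open speak of the compounds shown alone.

Compound 1 `O=c1cc(NC2CC2)cc(-c2ccccc2)o1`: > 30 uM
Compound 2 `COc1ccc(Nc2cc(C)oc(=O)c2)cc1`: > 30 uM
Compound 3 `COc1ccc(Nc2cc(C3CCCCC3)oc(=O)c2)cc1`: 8.61 uM

These compounds were tested in a functional assay on DU-145 cells (Homo sapiens) for cytotoxicity, read by MTT assay, with a stated time of 72 h; a higher number here means that more compound is needed for the effect, a lower number that less compound is needed. Compound 1 reports only a limit of the assay, > 30 uM. Compound 2 also reports only a limit, > 30 uM. Among the compounds with values here, compound 3, at 8.61 uM, therefore holds the only actual number so far.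

Within the data shown here, one measured step bears on what follows: an at least 3.4-fold lower number from compound 2 to compound 3 (0.54 log units; beyond the scatter), with cyclohexyl in place of methyl on an aromatic carbon. Compound 4 `CCCCCc1cc(Nc2ccc(OC)cc2)cc(=O)o1` changes the same group again: pentyl in place of cyclohexyl on an aromatic carbon, with pentyl in place of cyclohexyl on an aromatic carbon. Among the measured compounds shown here, the measured step compares cyclohexyl with methyl, and no measured step compares cyclohexyl with pentyl. No step beyond the scatter is therefore expected in this assay, in either direction. The expected step is a 1.2-fold higher number from compound 3 to compound 4 (0.06 log units; within the scatter). Compound 4 is estimated at 10 uM, with an expected range from 4.5 uM to 25 uM.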

Compound 4, concentration for half-maximal effect: 5.94 uM
Compound 4: middle estimate off by 1.7-fold (0.23 log units), on the high side, and the stated range covers the measured number.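

At this position, next to the ring oxygen, an open chain serves as well as a ring: in this assay there is a 1.4-fold lower number from compound 3 to compound 4 (0.16 log units; within the scatter), so pentyl and cyclohexyl cannot be told apart here. The effect of replacing the small methyl therefore does not depend on a ring, since the chain also gives an at least 5.0-fold lower number from compound 2 to compound 4 (0.70 log units; beyond the scatter). That step is a bound rather than an exact size, because compound 2 sits at a limit of the assay: the limit of > 30 uM in this assay, at which 2 of the 4 values shown sit.

The compounds shown leave open whether a longer chain, such as octyl, at this position would lower the number further in this assay or would raise it again. They also leave open whether an amine or a carboxylic acid at the end of the pentyl chain would keep the effect.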